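Aryl substituent change on compound 3

The source may hold more compounds than are shown below. What is called first, only, known or untested is meant among the compounds shown, and "the series" means these compounds.

Measured so far in a functional assay on the whole organism (strain albino) for inhibition, with Rattus norvegicus as the target, read by paw edema, with stated times of 30 min and 1 h, at a dose of 5 mg/kg by the oral route; on this read-out higher numbers stand for more inhibition at the one dose given (going by the name of the read-out) and lower numbers for less inhibition:
compound 1 `Nc1nc(CC(=O)O)n[nH]1` gives 22.3%
compound 2 `CCOC(=O)Cc1n[nH]c(N)n1` gives 25%
compound 3 `CCOC(=O)Cc1nc(N)n(C(=O)c2ccc(Cl)cc2)n1` gives 34.2%

Compound 3 stands highest of the three numbers; compound 2 lies within the scatter of it, compound 1 beyond. Within the data shown here, the only measured step, a number 2.7 percentage points higher from compound 1 to compound 2 (within the scatter), concerns the ester end and stays within the scatter; no measured step touches the benzoyl ring. Compound 4 `CCOC(=O)Cc1nc(N)n(C(=O)c2ccc(OC)cc2)n1` differs from compound 3 by methoxy in place of chloro on an aromatic carbon. Among the measured compounds shown here, no measured step bears on this change, so the step expected for a number 2.2 percentage points lower from compound 3 to compound 4 (within the scatter) is none beyond the scatter, with the range widened for want of a comparable pair. Compound 4 is expected to give 32%, between 20% and 45%.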

Compound 4, a percentage reported as inhibition, in the whole organism at one dose (the size of the read-out at that dose, not a potency): 32.8%
Beside the measured number, compound 4's estimate is 0.8 percentage points below it; the measured number falls inside the stated range.
By their numbers in this assay, from the lowest: compounds 1, 2, 4 and 3 (each within the scatter of the next, the first and the last beyond it).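

In this assay, methoxy in place of chloro on an aromatic carbon, para to a large group, gives a number 1.4 percentage points lower from compound 3 to compound 4 (within the scatter). Among these compounds, this is the first measured change on this ring, and at this one dose it shows no step beyond the scatter, despite the added heavy atom and hydrogen-bond acceptor. No measurement available explains the closeness of these two results.

Still open, as far as these compounds go, is whether an amine or a carboxylic acid at this position would give a step beyond the scatter. From the compounds shown here alone, whether the ring without any substituent would do so also remains open.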